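Hydroxyethyl homologue of compound 2: cytotoxicity working notes

The compounds below may be only part of what the source reports. "The series", "measured", "known", "first", "only" and "open" are said of these compounds alone.

Measured in an ADME assay on MT2 cells (Homo sapiens) for cytotoxicity, read by XTT assay, with a stated time of 4 days; on this read-out lower numbers stand for higher toxicity in this test and higher numbers for lower toxicity in this test:
- compound 1 `Cc1ccc(NC(=O)C(=O)NC(c2nc(C)c(CCO)s2)C2CCCCN2)c(F)c1`: > 78800 nM (a limit of the assay)
- compound 2 `Cc1nc(C(NC(=O)C(=O)Nc2ccc(Cl)c(F)c2)C2CCCCN2)sc1CO`: 77800 nM

Among the measured compounds shown here, compound 2 gives 77800 nM, the only exact number in this set. Compound 1 gives no exact number, only (the limit of > 78800 nM in this assay, at which 1 of the 2 values shown sits).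

Compound 3 `Cc1nc(C(NC(=O)C(=O)Nc2ccc(Cl)c(F)c2)C2CCCCN2)sc1CCO` is the next case. It has hydroxymethyl in place of hydroxy on a saturated chain carbon bound to an aromatic carbon, so the hydroxymethyl of compound 2 becomes 2-hydroxyethyl (hydroxymethyl in place of hydroxy on a saturated chain carbon bound to an aromatic carbon). For the measured compounds named here, no measured step covers this change, so the expectation rests on compound 2 at 77800 nM. No shift beyond the usual scatter is expected in this assay. The expected change is a 1.1-fold lower number from compound 2 to compound 3 (0.03 log units; within the scatter). Compound 3 is estimated at 72000 nM, with an expected range of 38000 nM to 110000 nM.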

Compound 3, half-maximal cytotoxic concentration: > 41000 nM
Compound 3: a limit, no number; the forecaster's own chance of this, stated with the estimate: 45%; the middle value lies beyond the limit too.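

In this assay compound 3 gives > 41000 nM, a limit and not a number. Among the compounds shown here, no step to compound 3 can be read, from compound 2 or from compound 1. Left open is whether the change from hydroxymethyl to 2-hydroxyethyl shifts the half-maximal cytotoxic concentration at all, and in which direction.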